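The source may hold more compounds than are shown below. What is called first, only, known or untested is meant among the compounds shown, and "the series" means these compounds.

Measured in a functional assay on MCF7 cells (Homo sapiens) for inhibition, read by MTT assay, with a stated time of 72 h; a higher number here means a weaker inhibitor, a lower number a stronger inhibitor:
- Compound 1 `COc1cccc(/C=C/C(=O)Nc2cc(OC)c(OC)c(OC)c2)c1`: 27000 nM
- Compound 2 `COc1cc(NC(=O)/C=C/c2cccc(OCc3ccccc3)c2)cc(OC)c1OC`: 2400 nM
- Compound 3 `C=C(Br)C(=O)Nc1cccc(/C=C/C(=O)Nc2cc(OC)c(OC)c(OC)c2)c1`: 1800 nM

Two compounds share the low end of these numbers: a 1.3-fold lower number from compound 2 to compound 3 (0.12 log units; within the scatter). Compound 3 stands well apart from the remaining one: a 15-fold lower number from compound 1 to compound 3 (1.18 log units; beyond the scatter).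

The next compound is compound 4 `COc1cc(NC(=O)/C=C/c2cccc(N)c2)cc(OC)c1OC`. The change is hydrogen in place of (1-bromoethenyl)carbonyl on a nitrogen on an aromatic ring, which leaves amino at that carbon.

Among the measured compounds shown here, no measured step makes this exact change. The closest guides are the two large steps away from methoxy: a 15-fold lower number from compound 1 to compound 3 (1.18 log units; beyond the scatter), and an 11-fold lower number from compound 1 to compound 2 (1.05 log units; beyond the scatter). Amino is nearest in size to the methoxy of compound 1, at 27000 nM, so most of the gain is expected to be lost. In this assay, the expected step is an 11-fold higher number from compound 3 to compound 4 (1.05 log units; beyond the scatter), a large rise beyond the scatter. The estimate for compound 4 is 20000 nM, with an expected range of 6000 nM to 60000 nM.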

Compound 4, half-maximal inhibitory concentration: 55400 nM
For compound 4 the middle estimate is 2.8-fold (0.44 log units) below the measured one; measured number inside the range.
By their numbers in this assay, from the lowest: compounds 3 and 2 (each within the scatter of the next); then compound 1; then compound 4.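

In this assay, taking the (1-bromoethenyl)carbonyl off the nitrogen on the aromatic ring removes the whole gain seen for compound 3 (a 31-fold higher number from compound 3 to compound 4 (1.49 log units; beyond the scatter)). Amino also falls far short of benzyloxy (a 23-fold higher number from compound 2 to compound 4 (1.36 log units; beyond the scatter)) and modestly short of methoxy (a 2.1-fold higher number from compound 1 to compound 4 (0.31 log units; beyond the scatter)), so compound 4 is the weakest of the four and a free nitrogen at this carbon brings no gain over any group tested there. No measurement here bears on the reason for these steps.

Still open, on these data alone, is which part of the (1-bromoethenyl)carbonyl carries the gain: acetyl or unbrominated acryloyl on the same nitrogen would separate the carbonyl, the double bond and the bromine. Also open, as far as these compounds go, is whether a methylamino or dimethylamino group at this carbon would behave like amino.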